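This account rests on a few compounds, and the source may have more. Where it says the series, first, only, none or still open, it means among the compounds named here.

Compound 1, `C=C[C@]1(C)C[C@@H](OC(=O)CNC(=O)Nc2ccc(OC)cc2)[C@]2(C)[C@H](C)CC[C@]3(CCC(=O)[C@H]32)[C@@H](C)[C@@H]1O`: > 10000 nM
Compound 2, `C=C[C@]1(C)C[C@@H](OC(=O)CNC(=O)Nc2ccc(F)cc2F)[C@]2(C)[C@H](C)CC[C@]3(CCC(=O)[C@H]32)[C@@H](C)[C@@H]1O`: > 10000 nM

In a functional assay on HT-29 cells (Homo sapiens) for inhibition, read by MTT assay, with a stated time of 72 h (on this read-out lower numbers stand for stronger inhibition and higher numbers for weaker inhibition), compound 1 gives > 10000 nM, which is a limit of the assay and not a number. Compound 2 gives > 10000 nM in this assay, again a limit. Within the data shown here, because of the limit of > 10000 nM in this assay, at which 2 of the 2 values shown sit, the only measured step, a step that the two limits leave unreadable from compound 1 to compound 2, cannot be read in either direction. So compound 1 stands at the limit, and the one compound beside it stands at the same limit.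

Compound 3, `C=C[C@]1(C)C[C@@H](OC(=O)CNC(=O)Nc2ccc(F)cc2)[C@]2(C)[C@H](C)CC[C@]3(CCC(=O)[C@H]32)[C@@H](C)[C@@H]1O`, keeps the shared core of compound 1 and differs from it in one place: fluoro in place of methoxy on an aromatic carbon. The measured step from compound 1 to compound 2 is the only one that bears on this change, since it also exchanges the group on the same aromatic ring, and because the limit of > 10000 nM in this assay, at which 2 of the 2 values shown sit, it gives no size to work from. Nothing shown points to a step beyond the scatter in this assay in either direction. Compound 3 is therefore expected to sit near the same limit, with the expected step being a step that the limit leaves unreadable from compound 1 to compound 3. The estimate for compound 3 is 15000 nM, in the range 5000 nM to 50000 nM.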

Compound 3, half-maximal inhibitory concentration: > 10000 nM
Compound 3 gave a limit, no number; the forecaster's own chance of this, stated with the estimate: 80%; the middle value does not contradict the limit.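

Compound 3 also sits at a limit and gives no number, so its steps to compound 1 and compound 2 cannot be read in this assay: the limit of > 10000 nM in this assay, at which 3 of the 3 values shown sit.

The compounds shown leave open whether any change to the aromatic ring or the shared core would give a measurable number in this assay.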